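A heteroaryl exchange at the amide carbonyl of compound 3

The source may report more compounds than this note shows. Statements on the series, on what has been measured and on what is new or still open speak of the compounds shown alone.

Compound 3 `CC(C)(C)c1cc(C(=O)Nc2cccc(NC(=O)COc3ccc4c(=O)ccoc4c3)c2)no1` gives 101 nM in an assay on isolated protein for inhibition of Rho-associated protein kinase 1 (Homo sapiens), read by scintillation counting, radiometric assay and 33P incorporation, with a stated time of 40 min, in the presence of a further agent that is not named here (on this read-out higher numbers stand for weaker inhibition and lower numbers for stronger inhibition), the lowest of the three numbers in hand; compound 2 `CCCc1ccc(C(=O)Nc2cccc(NC(=O)COc3ccc4c(=O)ccoc4c3)c2)cc1` gives 143 nM, and compound 1 `CCc1ccc(C(=O)Nc2cccc(NC(=O)COc3ccc4c(=O)ccoc4c3)c2)cc1` gives 235 nM. Compound 4 `O=C(COc1ccc2c(=O)ccoc2c1)Nc1cccc(NC(=O)c2cnc(C(F)(F)F)s2)c1` carries 2-(trifluoromethyl)-1,3-thiazol-5-yl in place of 5-(tert-butyl)-1,2-oxazol-3-yl on a carbonyl carbon. The two measured steps that alter the group on this carbonyl carbon bear on the change: a 2.3-fold lower number from compound 1 to compound 3 (0.37 log units; beyond the scatter), and a 1.4-fold lower number from compound 2 to compound 3 (0.15 log units; within the scatter). Among the compounds with values here, both were modest at most, and no measured pair tests an exchange of one five-membered aromatic ring with two hetero atoms for another. A step of no size beyond the scatter is therefore expected, a 1.3-fold higher number from compound 3 to compound 4 (0.11 log units; within the scatter). Compound 4 is estimated at 130 nM, within a range from 50 nM to 350 nM.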

Compound 4, half-maximal inhibitory concentration: 160 nM
For compound 4 the middle estimate is 1.2-fold (0.09 log units) below the measured one; the range from low to high includes it.
By their numbers in this assay, from the lowest: compounds 3, 2, 4 and 1 (each within the scatter of the next, the first and the last beyond it).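

In this assay, replacing one five-membered aromatic ring with two hetero atoms by another on this carbonyl carbon stays within the scatter (a 1.6-fold higher number from compound 3 to compound 4 (0.20 log units; within the scatter)), so this position accepts 2-(trifluoromethyl)-1,3-thiazol-5-yl as well as 5-(tert-butyl)-1,2-oxazol-3-yl. Compound 4 also stays within the scatter of both phenyl compounds (a 1.1-fold higher number from compound 2 to compound 4 (0.05 log units; within the scatter); a 1.5-fold lower number from compound 1 to compound 4 (0.17 log units; within the scatter)), even though compound 3 and compound 1 lie beyond it. Nothing available gives a reason for this tolerance. Going by these compounds, whether an amine or a carboxylic acid on this ring would keep the number in this range remains open. The compounds shown also do not separate the contribution of the thiazole ring from that of its trifluoromethyl group.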